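The source may hold more compounds than are shown below. What is called first, only, known or untested is meant among the compounds shown, and "the series" means these compounds.

Working notes on the series. Compound 1 `O=C(/C=C/C1CCCCC1)c1ccccc1` was tested in a functional assay on HBL-100 cells (Homo sapiens) for inhibition, read by sulforhodamine B assay, with a stated time of 48 h (on this read-out higher numbers stand for weaker inhibition of growth and lower numbers for stronger inhibition of growth), and gives 18000 nM. Compound 2 `O=C(/C(=C/c1ccc(Cl)cc1)CCl)c1ccccc1`, in the same assay, gives 3200 nM. Of the two numbers in hand, compound 2 holds the lower one, and the gap between the value of compound 2 and the value of compound 1 lies beyond the scatter of repeated measurements, so compound 2 is the stronger growth inhibitor of the pair. Among the measured compounds shown here, no pair of measured compounds differing in a single place exists yet, so no measured step can guide the next change.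

Compound 3 `CC(=O)OC/C(=C\c1ccc(Cl)cc1)C(=O)c1ccccc1` is the next member to be measured. It differs from compound 2 in one place: acetoxy in place of chloro on a saturated chain carbon bound to a double-bonded chain carbon. For the measured compounds named here, with no matched step in hand, the size of the change from compound 2 to compound 3 in this assay can only be guessed. The expectation for the step of a 1.6-fold higher number from compound 2 to compound 3 (0.19 log units; within the scatter) is a small move toward a higher number, close to the scatter rather than clearly beyond it. Compound 3 is therefore estimated at 5000 nM, with a range from 1500 nM to 16000 nM, to be checked once the measurement is known.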

Compound 3, concentration for 50% growth inhibition: 2300 nM
The estimate for compound 3 lay 2.2-fold (0.34 log units) above the measured number, within the range that was stated.
By their numbers in this assay, from the lowest: compounds 3 and 2 (each within the scatter of the next); then compound 1.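

In this assay, among the compounds shown here, the first matched step, a 1.4-fold lower number from compound 2 to compound 3 (0.14 log units; within the scatter), shows that on a saturated chain carbon bound to a double-bonded chain carbon, acetoxy in place of chloro leaves the growth inhibition indistinguishable within the scatter. The change is not a small one in atom count: 1 chlorine leaves, while 4 heavy atoms enter, with 2 hydrogen-bond acceptors and 1 double bond outside aromatic rings. For this pair, then, chloro is not required at this place for growth inhibition at this level, and chloromethyl and acetoxymethyl cannot be told apart on this read-out.

Still open, as far as these compounds go, is whether an amine, a carboxylic acid or a longer chain on the same saturated chain carbon would keep the read-out at this level or move it beyond the scatter. Also open, from the compounds shown here alone, is how much of the gap to compound 1 belongs to this place at all, since compound 1 differs from compound 2 in more than one place, and no measurement in hand explains why compound 2 and compound 3 read alike.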